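Anilide series: methoxy for methyl on the amide aryl

A few compounds are considered here, and "the series" means these few. Any claim that something is new, unique, unknown or untested is made for them only; others in the source may bear on it.

Measured compounds:
compound 1 `COc1cc2c(cc1OC)C(CC(=O)Nc1cccc(Cl)c1)CC2` gives 31.3%
compound 2 `COc1cc2c(cc1OC)C(CC(=O)Nc1ccc(Br)cc1)CC2` gives 50%
compound 3 `COc1cc2c(cc1OC)C(CC(=O)Nc1ccc(C)cc1)CC2` gives 34.4%

The three compounds share one core and differ only in the aryl group on the amide-type nitrogen. In a functional assay on the whole organism (strain Wistar) for inhibition, with Rattus norvegicus as the target, read by paw edema, with a stated time of 1 h, at a dose of 100 mg/kg (a higher number here means more inhibition at the dose given (going by the name of the read-out), a lower number less inhibition), compound 3 stands second highest of the three numbers, but its nearest neighbour is compound 1, and the step of a number 3.1 percentage points higher from compound 1 to compound 3 (within the scatter) lies within the scatter, so these two cannot be ordered. For the measured compounds named here, the only step beyond the scatter runs to compound 2: a number 15.6 percentage points lower from compound 2 to compound 3 (beyond the scatter) and a number 18.7 percentage points higher from compound 1 to compound 2 (beyond the scatter) both set compound 2 apart from the other two.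

Compound 4 `COc1ccccc1NC(=O)CC1CCc2cc(OC)c(OC)cc21` follows from compound 3 by the change (2-methoxyphenyl in place of 4-methylphenyl on an amide-type nitrogen). Going by the values given here, none of the measured steps swaps a methyl for a methoxy or places a group where the incoming methoxy sits, so no step bears directly on this change. What the series shows is that the two aryl groups without bromo, in compound 1 and compound 3, sit within the scatter of each other, while bromo alone lifts the number modestly. On that basis the expected step of a number 1.4 percentage points lower from compound 3 to compound 4 (within the scatter) is none beyond the scatter. Compound 4 is therefore estimated at 33%, with a range from 17% to 49%.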

Compound 4, a percentage reported as inhibition, in the whole organism at one dose (the size of the read-out at that dose, not a potency): 28.1%
Compound 4: middle estimate off by 4.9 percentage points, on the high side; the range from low to high includes it.
By their numbers in this assay, from the lowest: compounds 4, 1 and 3 (each within the scatter of the next); then compound 2.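

In this assay, 2-methoxyphenyl on the amide-type nitrogen falls in with the two aryl groups that carry no bromo: neither a number 6.3 percentage points lower from compound 3 to compound 4 (within the scatter) nor a number 3.2 percentage points lower from compound 1 to compound 4 (within the scatter) allows compound 4 to be ordered against those compounds. The step of a number 21.9 percentage points lower from compound 2 to compound 4 (beyond the scatter) sets compound 2 apart from a third aryl group, so its steps to all three other compounds are now beyond the scatter, and the one hydrogen-bond acceptor that enters with the 2-methoxyphenyl group goes with no step beyond the scatter from compound 3 or compound 1. Nothing available accounts for any of these numbers at this position.

Still open, on these data alone, is whether the number for compound 2 belongs to bromo itself or to its place in the 4-bromophenyl group, a question that 3-bromophenyl and 4-chlorophenyl anilides would address, with 4-methoxyphenyl testing the methoxy group in that same place. Also open, as far as these compounds go, is whether an aryl group carrying an amine or a carboxylic acid would stay within the scatter of compound 3 or move beyond it.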